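The source may report more compounds than this note shows. Statements on the series, on what has been measured and on what is new or still open speak of the compounds shown alone.

Three compounds have been measured in an ADME assay on Caco-2 cells (Homo sapiens) for permeability, read by LC-MS, in the apical to basolateral direction, with a stated time of 60 min, at pH 6.5; a higher number here means that the compound crosses the layer faster, a lower number that the compound crosses the layer more slowly:

compound 1, `CCCC[C@@H](O)C(=O)N1C[C@H]2C[C@H]2[C@H]1C(=O)NCc1cc(Cl)ccc1-n1cnnn1`, 33 10^-6 cm/s
compound 2, `CC(C)(C)[C@@H](O)C(=O)N1N=CC[C@H]1C(=O)NCc1cc(Cl)ccc1-n1cnnn1`, 15 10^-6 cm/s
compound 3, `CC(C)(C)[C@@H](O)C(=O)N1C[C@H]2C[C@H]2[C@H]1C(=O)NCc1cc(Cl)ccc1-n1cnnn1`, 3.8 10^-6 cm/s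

Compound 4, `CCCC[C@@H](O)C(=O)N1N=CC[C@H]1C(=O)NCc1cc(Cl)ccc1-n1cnnn1`, has not yet been measured. It is made from compound 2 by the change (butyl in place of tert-butyl on a saturated chain carbon bound to a carbonyl carbon and an oxygen on a saturated carbon). The same change leads from compound 3 to compound 1, where it gave an 8.7-fold higher number from compound 3 to compound 1 (0.94 log units; beyond the scatter). Compound 1 and compound 3 share one core, compound 2 and compound 4 another; the difference between the two cores is not broken down here. The change occurs only twice among these compounds, so its effect on the second core rests on a single earlier step. Compound 2 already shows a higher number than compound 3, so a somewhat smaller step is expected: the estimated step from compound 2 to compound 4 is a 2.7-fold higher number from compound 2 to compound 4 (0.43 log units; beyond the scatter), because the earlier step was an 8.7-fold higher number from compound 3 to compound 1 (0.94 log units; beyond the scatter). Compound 4 is therefore expected at 40 10^-6 cm/s, most likely between 15 10^-6 cm/s and 100 10^-6 cm/s.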

Compound 4, apparent permeability: 9.8 10^-6 cm/s
Compound 4: middle estimate off by 4.1-fold (0.61 log units), on the high side; the measured number lies below the stated range.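

In this assay, putting butyl in place of tert-butyl gave a 1.5-fold lower number from compound 2 to compound 4 (0.18 log units; within the scatter), so on this core the swap makes no difference that can be told from the usual scatter. Set beside the earlier step, the same change clearly does not carry over from one core to the other: the same change on two cores in this assay, an 8.7-fold higher number (0.94 log units; beyond the scatter) from compound 3 to compound 1 and a 1.5-fold lower number (0.18 log units; within the scatter) from compound 2 to compound 4, 13-fold (1.12 log units) apart, beyond the scatter of two such steps. This shows that a step seen on one core cannot be assumed on the other, but two pairs do not show which feature of the cores lies behind the gap, nor what a third core would do.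

The compounds shown leave open how a longer chain, such as hexyl, would read in place of butyl on either core. They also leave open whether a chain carrying an amine would follow either step.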